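This account rests on a few compounds, and the source may have more. Where it says the series, first, only, none or still open, it means among the compounds named here.

Compound 1 `c1ccc(C(CCC/N=C(/NCCCc2c[nH]cn2)NC2CCCCC2)c2ccccn2)cc1`: in a functional assay on cardiac atrium for agonist activity at histamine H2 receptor (Cavia porcellus) (on this read-out lower numbers stand for lower potency and higher numbers for higher potency (the scale is a negative logarithm)), compound 1 gives 4.49.
Compound 2 `CN/C(=N\CCCC(c1ccc(Cl)c(Cl)c1)c1ccccn1)NCCCc1c[nH]cn1`: in this assay compound 2 gives 5.58.

Compound 2 holds the higher of the two numbers; compound 1 lies beyond the scatter below it. Compound 3 `Clc1ccc(C(CCC/N=C(/NCCCc2c[nH]cn2)NC2CCCCC2)c2ccccn2)cc1Cl` keeps the core of compound 2 and differs in one place: cyclohexyl in place of methyl on an amine nitrogen. Within the data shown here, no measured pair isolates this change, since compound 1 and compound 2 differ at two sites, so the size and direction of the step in this assay are open. A modest loss is expected, given as a number 0.28 log units lower from compound 2 to compound 3 (within the scatter). Compound 3 is estimated at 5.3, in the range 4.6 to 6.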

Compound 3, negative logarithm of the half-maximal effective concentration: 4.65
The estimate for compound 3 lay 0.65 log units above the measured number, and the stated range covers the measured number.
By their numbers in this assay, from the lowest: compounds 1 and 3 (each within the scatter of the next); then compound 2.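

In this assay, the change from methylamino to cyclohexylamino can now be read at a single site: with 3,4-dichlorophenyl held constant, cyclohexyl in place of methyl gives a number 0.93 log units lower from compound 2 to compound 3 (beyond the scatter). With cyclohexyl held constant, 3,4-dichlorophenyl in place of phenyl gives a number 0.16 log units higher from compound 1 to compound 3 (within the scatter), so this swap shows no separable effect on the cyclohexylamino compounds. No data bearing on the cause of either step are available.

From the compounds shown here alone, how ethyl or cyclopropyl on that amine nitrogen would compare with methyl and cyclohexyl remains open. Also open, going by these compounds, is whether 3,4-dichlorophenyl in place of phenyl behaves the same way with methylamino present.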